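A few compounds are considered here, and "the series" means these few. Any claim that something is new, unique, unknown or untested is made for them only; others in the source may bear on it.

Measured so far:

Compound 1, `CCOC(=O)c1cc(CCCOc2ccc(-c3noc(C(F)(F)F)n3)cc2)on1`, in an ADME assay on HeLa cells (Homo sapiens) for cytotoxicity, read by crystal violet staining, with a stated time of 72 h (on this read-out lower numbers stand for higher toxicity in this test and higher numbers for lower toxicity in this test), gives > 100000 nM, which is a limit of the assay and not a number.
Compound 2, `CN(C)C(=O)c1cc(CCCOc2ccc(-c3noc(C(F)(F)F)n3)cc2)on1`, in this assay gives 28000 nM.
Compound 3, `CCOC(=O)c1cc(CCCOc2ccc(-c3noc(C(F)(F)F)n3)cn2)on1`, in this assay gives > 100000 nM, again a limit of the assay rather than a number.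

Compound 1 and compound 2 share a core and differ in one place: dimethylamino in place of ethoxy on a carbonyl carbon. In this assay this change made an at least 3.5-fold lower number from compound 1 to compound 2 (0.55 log units; beyond the scatter). The size of that step can only be given as a lower bound because the limit of > 100000 nM in this assay, at which 2 of the 3 values shown sit, leaves compound 1 without a number of its own. Compound 3 carries a different core from compound 1; how the two cores differ is not broken down here.

Compound 4, `CN(C)C(=O)c1cc(CCCOc2ccc(-c3noc(C(F)(F)F)n3)cn2)on1`, has not yet been measured in this assay. It stands to compound 3 exactly as compound 2 stands to compound 1: dimethylamino in place of ethoxy on a carbonyl carbon. The place of the change is described in the same words in both pairs, so this is the same change, not merely a similar one. On the strength of the step from compound 1 to compound 2, compound 4 is expected to show an at least 3.3-fold lower number from compound 3 to compound 4 (0.52 log units; beyond the scatter) in this assay. Compound 3 gives only a limit, so where compound 4 will land can be estimated only loosely; compound 4 is expected to fall near 30000 nM, with a plausible range from 10000 nM to 100000 nM.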

Compound 4, half-maximal cytotoxic concentration: 48800 nM
Compound 4: the middle estimate sits 1.6-fold (0.21 log units) below what was measured; the measured number falls inside the stated range.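

In this assay, dimethylamino in place of ethoxy on a carbonyl carbon gave an at least 2.0-fold lower number from compound 3 to compound 4 (0.31 log units; beyond the scatter), so in both pairs the compound carrying dimethylamino has the lower number, which on this read-out means higher toxicity in this test, and the direction of the change carried over from the core of compound 1 to the core of compound 3. Set side by side, the two steps read: the same change on two cores in this assay, an at least 3.5-fold lower number (0.55 log units; beyond the scatter) from compound 1 to compound 2 and an at least 2.0-fold lower number (0.31 log units; beyond the scatter) from compound 3 to compound 4; the limit leaves it open whether they differ What this does not show is whether the change has the same size on both cores, and two cores are too few to promise the same direction on a third, because the ethoxy compounds of both pairs give no number of their own, only a limit of the assay: the limit of > 100000 nM in this assay, at which 2 of the 4 values shown sit.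

The compounds shown leave open whether other groups on the same carbonyl carbon would move the number in the same way, for example a methylamino group, a ring amine such as morpholine, or the hydroxyl of a carboxylic acid. They also leave open how far the ethoxy compounds actually lie from their dimethylamino partners, and a longer chain in the linker is another change on which they give no guidance.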